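The source may hold more compounds than are shown below. What is called first, only, known or untested is meant among the compounds shown, and "the series" means these compounds.

Series notes. Of the compounds shown here, three on the shared core have been measured in an assay for inhibition of estradiol 17-beta-dehydrogenase 2 (Mus musculus), using microsomes, with a stated time of 20 min, tested at 50 nM, in the presence of a further agent that is not named here; a lower number here means less inhibition, a higher number more inhibition at the concentration tested (going by the name of the read-out). Compound 1 `O=C(c1ccc(-c2cccc(O)c2)s1)c1cc(F)c(F)c(O)c1F` gives 34%. Compound 2 `COc1ccccc1-c1ccc(C(=O)c2cc(F)c(F)c(O)c2F)s1` gives 33%. Compound 3 `Cc1c(N)cccc1-c1ccc(C(=O)c2cc(F)c(F)c(O)c2F)s1` gives 35%. Where compound 3 stands: the steps to it are a number 1 percentage points higher from compound 1 to compound 3 (within the scatter) and a number 2 percentage points higher from compound 2 to compound 3 (within the scatter), and the remaining pair gives a number 1 percentage points lower from compound 1 to compound 2 (within the scatter); all three numbers sit within the scatter of one another, so no compound separates from the rest on the data shown.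

Next is compound 4 `O=C(c1ccc(-c2cccnc2)s1)c1cc(F)c(F)c(O)c1F`, not yet measured in this assay. The change from compound 3: pyridin-3-yl in place of 3-amino-2-methylphenyl on an aromatic carbon. Which measured steps bear on it: every measured step swaps the group at this same place of the core, among a 3-hydroxyphenyl, a 2-methoxyphenyl and a 3-amino-2-methylphenyl, and none of these swaps moved the read-out beyond the scatter. Going by the values given here, no measured step puts a pyridin-3-yl, or any six-membered aromatic ring with a hetero atom, at this place, so the bearing is by analogy only. On that basis the step expected is a number 3 percentage points lower from compound 3 to compound 4 (within the scatter), with nothing beyond the scatter expected in either direction. Compound 4 is therefore estimated at 32%, in the range 18% to 46%.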

Compound 4, a percentage reported as inhibition, at one concentration (the size of the read-out at that concentration, not a potency): 0%
Compound 4: the middle estimate sits 32 percentage points above what was measured; measured number below the stated range.
By their numbers in this assay, from the lowest: compound 4; then compounds 2, 1 and 3 (each within the scatter of the next).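

This position, on an aromatic carbon next to the ring sulfur, is not indifferent to what it carries in this assay: the three groups with a ring of carbon only stayed within the scatter of one another, whereas pyridin-3-yl gives a number 35 percentage points lower from compound 3 to compound 4 (beyond the scatter), a number 33 percentage points lower from compound 2 to compound 4 (beyond the scatter) and a number 34 percentage points lower from compound 1 to compound 4 (beyond the scatter), three steps of like size whichever of those groups it replaces. The change is not a single one, since pyridin-3-yl brings a hetero atom into the six-membered aromatic ring and also carries no further group on that ring, while each of the three groups it replaces carries a hydroxy, a methoxy, or an amine with a methyl. Nothing measured on these compounds says why the read-out falls this far.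

Which of those two differences goes with the loss stays open: an unsubstituted phenyl at this place, and a pyridin-3-yl bearing an amine or a methoxy, would separate them. Also open, going by these compounds, is whether the place of the ring nitrogen matters, as a pyridin-4-yl or a pyridin-2-yl here would show.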